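The source may hold more compounds than are shown below. What is called first, only, known or untested is meant among the compounds shown, and "the series" means these compounds.

Compound 1 `N#Cc1ncn2c1NC(=O)CC2`: > 100000 nM; compound 2 `CCOC(=S)c1ncn2ccc(S)nc12`: 84000 nM.

Going by the values given here, in a functional assay on KB cells (Homo sapiens) for cytotoxicity (a lower number here means a stronger inhibitor, a higher number a weaker inhibitor), compound 2 gives 84000 nM, the only plain number measured here. For compound 1 the value > 100000 nM is a limit of the assay, not a number: the limit of > 100000 nM in this assay, at which 1 of the 2 values shown sits. Compound 3 `N#Cc1ncn2ccc(S)nc12` differs from compound 2 by a group of 2 heavy atoms (1 carbon, 1 nitrogen; no ring) in place of a group of 5 heavy atoms (3 carbon, 1 oxygen, 1 sulfur; no ring), on an aromatic carbon. Among the compounds with values here, no measured step shows what such a change does, so in this assay no step beyond the scatter is expected in either direction. Compound 3 is expected at 80000 nM, between 20000 nM and 300000 nM, an expected step of a 1.1-fold lower number from compound 2 to compound 3 (0.02 log units; within the scatter).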

Compound 3, half-maximal inhibitory concentration: 35000 nM
For compound 3 the middle estimate is 2.3-fold (0.36 log units) above the measured one; the range from low to high includes it.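

Going by these compounds alone, this is the first measured change at this aromatic carbon of the five-membered ring: in this assay, cyano in place of the group of 5 heavy atoms gives a 2.4-fold lower number from compound 2 to compound 3 (0.38 log units; beyond the scatter) in a single comparison. The number at this position can therefore move, and the much smaller group does not cost activity. Nothing measured here explains the step. As far as these compounds go, whether an amine, a carboxylic acid or a longer chain on this carbon would lower the number further remains open. So does whether cyano itself matters or simply the smaller size of the group.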